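A few compounds are considered here, and "the series" means these few. Any claim that something is new, unique, unknown or untested is made for them only; others in the source may bear on it.

Compound 1, `COC(=O)c1c(N)sc(-c2ccc(Cl)cc2)c1-c1ccc(Cl)cc1`, was tested in a functional assay on PC-3 cells (Homo sapiens) for cytotoxicity, read by sulforhodamine B assay, with a stated time of 72 h (on this read-out higher numbers stand for weaker inhibition and lower numbers for stronger inhibition), where compound 1 gives 2780 nM. Of the two compounds with a number in this assay, compound 1 has the lower one: compound 2, `Nc1sc(-c2ccc([N+](=O)[O-])cc2)c(-c2ccc(Cl)cc2)c1C(=O)NC1CCCCC1`, gives 25900 nM, a gap beyond the usual scatter. Compound 3, `Nc1sc(-c2ccc([N+](=O)[O-])cc2)c(-c2ccc(Cl)cc2)c1C(=O)N1CCCCC1`, has no number in this assay, reported as "not determined" (no result reported).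

Compound 4, `Nc1sc(-c2ccc(Cl)cc2)c(-c2ccc(Cl)cc2)c1C(=S)NC1CC1`, differs from compound 1 in one place: a group of 6 heavy atoms (4 carbon, 1 nitrogen, 1 sulfur; one three-membered non-aromatic ring of carbon only) in place of a group of 4 heavy atoms (2 carbon, 2 oxygen; no ring), on an aromatic carbon. Among the compounds with values here, both pairs of rings stay the same, so only this exchange is in question.

Within the data shown here, no measured pair shows this exchange on its own, so the expectation is uncertain. The step from compound 1 to compound 4 is estimated as a 1.8-fold higher number from compound 1 to compound 4 (0.25 log units; within the scatter), a mild weakening. Compound 4 is therefore expected to give about 5000 nM, most likely between 1200 nM and 20000 nM.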

Compound 4, half-maximal inhibitory concentration: 22100 nM
Compound 4: middle estimate off by 4.4-fold (0.65 log units), on the low side; the measured number lies above the stated range.
By their numbers in this assay, from the lowest: compound 1; then compounds 4 and 2 (each within the scatter of the next).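

Exchanging the methoxycarbonyl group on this aromatic carbon for the group with the three-membered ring gives a 7.9-fold higher number from compound 1 to compound 4 (0.90 log units; beyond the scatter) in this assay. This position on the shared core is therefore not indifferent to what it carries, and this exchange moves the number in the weaker direction. No available evidence accounts for the step.

From the compounds shown here alone, the exchange brings in sulfur, nitrogen and the ring together, so the part that matters stays open. Going by these compounds, whether a cyclopropyl amide with a carbonyl oxygen in place of the sulfur, or a carboxylic acid, would behave the same also remains open.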